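Weak antiproliferative butenolides: a sulfonamide replaces a hydroxymethyl

The source may report more compounds than this note shows. Statements on the series, on what has been measured and on what is new or still open speak of the compounds shown alone.

Measured so far:
compound 1, `CCCCc1cn(C[C@H](O)[C@H]2OC(=O)C(OCc3ccccc3)=C2OCc2ccccc2)nn1`, 73200 nM in a functional assay on CFPAC-1 cells (Homo sapiens) for antiproliferative activity, read by MTT assay, with a stated time of 72 h; a higher number here means a weaker inhibitor, a lower number a stronger inhibitor
compound 2, `O=C1O[C@H]([C@@H](O)Cn2cc(CCO)nn2)C(OCc2ccccc2)=C1OCc1ccccc1`

In this assay compound 2 gives only a limit, > 100000 nM. Compound 2 thus stands at the limit of > 100000 nM in this assay, at which 1 of the 2 values shown sits, the weaker end of the pair. Among the measured compounds shown here, the single measured step, an at least 1.3-fold higher number from compound 1 to compound 2 (0.13 log units; that floor lies within the scatter), changed a chain substituent far from the site now altered and lies within the scatter, so it offers little guidance. Compound 3, `O=C1O[C@H]([C@@H](O)Cn2cc(CNS(=O)(=O)c3ccc(Cl)cc3F)nn2)C(OCc2ccccc2)=C1OCc1ccccc1`, carries ((4-chloro-2-fluorophenyl)sulfonyl)amino in place of hydroxymethyl on a saturated chain carbon bound to an aromatic carbon. For the measured compounds named here, with no step of comparable size measured, compound 3 is expected to give about 30000 nM, within 5000 nM to 150000 nM, that is an expected step of an at least 3.3-fold lower number from compound 2 to compound 3 (0.52 log units; beyond the scatter).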

Compound 3, half-maximal inhibitory concentration: 58200 nM
For compound 3 the middle estimate is 1.9-fold (0.29 log units) below the measured one; low and high end bracket the measured number.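

In this assay, among the compounds shown here, ((4-chloro-2-fluorophenyl)sulfonyl)amino on the saturated chain carbon bound to an aromatic carbon gives an at least 1.7-fold lower number from compound 2 to compound 3 (0.23 log units; that floor lies within the scatter), so the first sulfonylamino group at this position brings no gain that can be told from the scatter. Set against propyl at the same carbon, the same group gives a 1.3-fold lower number from compound 1 to compound 3 (0.10 log units; within the scatter), so those two compounds do not separate. Compound 2 gives only a limit, not a number: the limit of > 100000 nM in this assay, at which 1 of the 3 values shown sits.

As far as these compounds go, what remains open is whether an amine or a carboxylic acid on this carbon would move the number beyond the scatter. Also open, from the compounds shown here alone, is what an unsubstituted phenyl on the sulfonyl group would do.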